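The source may report more compounds than this note shows. Statements on the series, on what has been measured and on what is new or still open speak of the compounds shown alone.

Measured so far in a functional assay on MCF7 cells (Homo sapiens) for cytotoxicity, read by sulforhodamine B assay, with a stated time of 48 h; a lower number here means a stronger inhibitor, a higher number a weaker inhibitor:

Compound 1, `COc1ccc(/C=C/C(=O)c2cccc(-c3ccc(F)cc3)c2)cc1`: 16400 nM
Compound 2, `COc1ccc(/C=C/C(=O)c2ccc(N)c(-c3ccc(F)cc3)c2)cc1`: 7580 nM
Compound 3, `COc1ccc(/C=C/C(=O)c2ccc(N)c(-c3ccc(F)cc3)c2)cc1OC`: 15000 nM

All three compounds share the same core and differ only at two positions. Compound 3 differs from compound 2 by methoxy in place of hydrogen on an aromatic carbon, and the resulting step, a 2.0-fold higher number from compound 2 to compound 3 (0.30 log units; within the scatter), is small. Compound 1 differs from compound 2 by hydrogen in place of amino on an aromatic carbon, and here the measured step, a 2.2-fold higher number from compound 2 to compound 1 (0.34 log units; beyond the scatter), is modest but real. The values of compound 1 and compound 3 are close to each other.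

Compound 4, `COc1ccc(/C=C/C(=O)c2cccc(-c3ccc(F)cc3)c2)cc1OC`, has not yet been measured. For the measured compounds named here, it differs from compound 3 by hydrogen in place of amino on an aromatic carbon, which is the same change, at the same kind of place, as the one already seen between compound 2 and compound 1. The step from compound 3 to compound 4 is expected to be a 2.0-fold higher number from compound 3 to compound 4 (0.30 log units; within the scatter), resting on the measured step of a 2.2-fold higher number from compound 2 to compound 1 (0.34 log units; beyond the scatter), since the change in both cases removes the same group from the same position. Compound 4 is therefore expected to give 30000 nM in this assay, with a likely range from 15000 nM to 60000 nM.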

Compound 4, half-maximal inhibitory concentration: 11600 nM
Estimate against measurement, compound 4: 2.6-fold (0.41 log units) above; measured number outside the range, below it.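

In this assay, hydrogen in place of amino now gives a 1.3-fold lower number from compound 3 to compound 4 (0.11 log units; within the scatter), so this change does not carry over at its earlier size from the core without the extra methoxy to the core with it: the same change on two cores in this assay, a 2.2-fold higher number (0.34 log units; beyond the scatter) from compound 2 to compound 1 and a 1.3-fold lower number (0.11 log units; within the scatter) from compound 3 to compound 4, 2.8-fold (0.45 log units) apart, beyond the scatter of two such steps. Methoxy in place of hydrogen likewise gives a 1.4-fold lower number from compound 1 to compound 4 (0.15 log units; within the scatter) on the core without the amino group, which does not match its step on the core with that group: the same change on two cores in this assay, a 2.0-fold higher number (0.30 log units; within the scatter) from compound 2 to compound 3 and a 1.4-fold lower number (0.15 log units; within the scatter) from compound 1 to compound 4, 2.8-fold (0.45 log units) apart, beyond the scatter of two such steps. Both comparisons rest on the same four compounds, so together they form one finding rather than two: in this small set, the step for one group depends on whether the other is present, but the data do not show why this happens or whether it holds beyond these compounds.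

The compounds shown leave open whether a hydroxyl or methylamino group in the place of the amino group would show the same dependence. They also leave open what a longer chain, such as ethoxy, would do in the place of the added methoxy.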